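The source may hold more compounds than are shown below. What is called first, only, known or untested is meant among the compounds shown, and "the series" means these compounds.

The series shares one core; compound 1 `COc1ccc(C#N)cc1S(=O)(=O)Nc1cnc2ccccc2c1` carries a nitrile, compound 2 `COc1ccc(C(F)(F)F)cc1S(=O)(=O)Nc1cnc2ccccc2c1` a trifluoromethyl, and compound 3 `COc1ccc(Cl)cc1S(=O)(=O)Nc1cnc2ccccc2c1` a chloro. In an assay on isolated protein for inhibition of alkaline phosphatase, tissue-nonspecific isozyme (Homo sapiens) (on this read-out lower numbers stand for stronger inhibition and higher numbers for weaker inhibition), compound 1 gives "not determined" (no result reported). In this assay compound 2 gives > 20000 nM, which is a limit of the assay and not a number. Compound 2 thus stands at the limit of > 20000 nM in this assay, at which 1 of the 2 values shown sits, and no second numbered value sits beside it in this set. Within the data shown here, no step between two measured compounds is known here, so the size of any change can only be expected, not read from the data. The change from compound 2 to compound 3 is chloro in place of trifluoromethyl on an aromatic carbon. With compound 2 sitting at its limit, no step beyond the scatter is expected, and the step from compound 2 to compound 3 is estimated as a number no higher from compound 2 to compound 3 (the limit leaves the size open). Compound 3 is expected at 20000 nM, within 5000 nM to 100000 nM, with a fair chance that only a limit is returned again.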

Compound 3, half-maximal inhibitory concentration: 4510 nM
For compound 3 the middle estimate is 4.4-fold (0.65 log units) above the measured one; measured number below the stated range.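

In this assay, among these compounds, compound 3 gives 4510 nM, the first numbered value in this set, so a group at this position, para to a methoxy group, is compatible with measurable inhibition on the shared core. Chloro in place of trifluoromethyl on an aromatic carbon gives an at least 4.4-fold lower number from compound 2 to compound 3 (0.64 log units; beyond the scatter), so the read-out responds to the group at this position. The full size of that step stays unread, as compound 2 holds a limit and not a number: the limit of > 20000 nM in this assay, at which 1 of the 3 values shown sits.

Steps involving the nitrile of compound 1 cannot be read, so its place relative to chloro and trifluoromethyl remains open. Also open, as far as these compounds go, is how fluoro, an amine or a carboxylic acid at this position would read, and whether any of them would go beyond chloro.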